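The source may report more compounds than this note shows. Statements on the series, on what has been measured and on what is new or still open speak of the compounds shown alone.

Measured in a functional assay on CCRF-CEM cells (Homo sapiens) for antiproliferative activity, read by fluorescence and resazurin assay, with a stated time of 48 h; a lower number here means a stronger inhibitor, a higher number a weaker inhibitor:
compound 1 `CCOc1ccc2nc(Cl)c(/C=N/NC(=O)c3cc4ccccc4oc3=O)cc2c1` gives 6320 nM;
compound 2 `CCOc1ccc(NC(=O)c2cc3ccc(O)cc3oc2=O)cc1` gives 12600 nM;
compound 3 `CCOc1ccc(NC(=O)c2cc3ccccc3oc2=O)cc1` gives 17900 nM.

Compound 4 `CCOc1ccc2nc(Cl)c(/C=N/NC(=O)c3cc4ccc(O)cc4oc3=O)cc2c1` is not yet measured. It is drawn from compound 1 by hydroxy in place of hydrogen on an aromatic carbon. The same change is already made from compound 3 to compound 2, (hydroxy in place of hydrogen on an aromatic carbon), where it gave a 1.4-fold lower number from compound 3 to compound 2 (0.15 log units; within the scatter). The difference between the core of compound 1 and the core of compound 3 is not broken down here. Compound 1 and compound 2 lie within the scatter of each other in this assay, while compound 3 lies beyond it from compound 1.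

Because the hydroxy gave only a 1.4-fold lower number from compound 3 to compound 2 (0.15 log units; within the scatter), the step from compound 1 to compound 4 is expected to be of about the same size, a 1.4-fold lower number from compound 1 to compound 4 (0.15 log units; within the scatter). Compound 4 is therefore estimated at 4500 nM in this assay, expected between 2000 nM and 12000 nM.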

Compound 4, half-maximal inhibitory concentration: 17100 nM
Compound 4: the middle estimate sits 3.8-fold (0.58 log units) below what was measured; measured number outside the range, above it.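

In this assay, the step for hydroxy in place of hydrogen on an aromatic carbon did not carry over from one core to the other: the same change on two cores in this assay, a 1.4-fold lower number (0.15 log units; within the scatter) from compound 3 to compound 2 and a 2.7-fold higher number (0.43 log units; beyond the scatter) from compound 1 to compound 4, 3.8-fold (0.58 log units) apart, beyond the scatter of two such steps. The new step is a 2.7-fold higher number from compound 1 to compound 4 (0.43 log units; beyond the scatter), so the step on one core gave no reliable guide to the step on the other. This shows that the size of the step differs between these two cores, but it does not show why, and one pair of steps sets no rule for other cores in the series.

From the compounds shown here alone, it remains open whether a methoxy or an amine at the same place would give similar steps on both cores or differ between them as the hydroxy does.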